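The compounds below may be only part of what the source reports. "The series", "measured", "known", "first", "only" and "open" are said of these compounds alone.

Compound 1 `O=C1C2=C(C(=O)c3ncccc31)C1(CS2)NC(=O)N(c2ccccc2)C1=O` gives 1510 nM in a functional assay on XF498 cells (Homo sapiens) for antiproliferative activity, read by MTT assay, with a stated time of 96 h (on this read-out higher numbers stand for weaker inhibition and lower numbers for stronger inhibition), the lower of the two numbers measured; compound 2 `O=C1NN(c2ccccc2)C(=O)C2(CSC3=C2C(=O)c2ncccc2C3=O)N1` gives 4550 nM in this assay, a gap beyond the usual scatter. Compound 3 `Cc1ccc(N2C(=O)NC3(CSC4=C3C(=O)c3ncccc3C4=O)C2=O)cc1` differs from compound 1 by one change: methyl in place of hydrogen on an aromatic carbon. Among the measured compounds shown here, with no measured pair showing what this change does, the step from compound 1 to compound 3 in this assay is expected to be small, a 1.0-fold lower number from compound 1 to compound 3 (0.00 log units; within the scatter), not beyond the scatter in either direction. Compound 3 is estimated at 1500 nM in this assay, within a range from 700 nM to 3500 nM.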

Compound 3, half-maximal inhibitory concentration: 1350 nM
For compound 3 the middle estimate is 1.1-fold (0.05 log units) above the measured one; the measured number falls inside the stated range.
By their numbers in this assay, from the lowest: compounds 3 and 1 (each within the scatter of the next); then compound 2.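

In this assay, among the compounds shown here, replacing phenyl with 4-methylphenyl gives a 1.1-fold lower number from compound 1 to compound 3 (0.05 log units; within the scatter), the first measured reading for this position, on an aromatic carbon para to a large group. Compounds 1 and 3 therefore read alike, and this position accepts a methyl with no step beyond the scatter. Nothing available accounts for this result. On these data alone, whether an amine, a carboxylic acid or a longer chain at this position would read alike or move the number remains open. So does the outcome of a methyl on the other carbons of this ring.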